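Trimming the Amide Substituent from Isopropyl to Ethyl

A few compounds are considered here, and "the series" means these few. Any claim that something is new, unique, unknown or untested is made for them only; others in the source may bear on it.

Measured so far:
Compound 1, `CCN(Cc1cccn1C)C(=O)COc1ccc(C)cc1`, gives 21300 nM.
Compound 2, `Cc1ccc(OCC(=O)N(CCCO)Cc2cccs2)cc1`, gives 3000 nM.
Compound 3, `Cc1ccc(OCC(=O)N(Cc2cccs2)C(C)C)cc1`, gives 70 nM.

In an assay on HEK293 cells for agonist activity at transient receptor potential cation channel subfamily M member 8 (Homo sapiens), read by fluorescence and calcium flux, with a stated time of 15 min (a higher number here means that more compound is needed for the effect, a lower number that less compound is needed), compound 3 stands lowest of the three numbers, well clear of both others. Within the data shown here, the only measured step that bears on the change at hand is a 43-fold lower number from compound 2 to compound 3 (1.63 log units; beyond the scatter), a large gain from the isopropyl in place of 3-hydroxypropyl on an amide-type nitrogen. It shows that the group on this nitrogen matters a great deal.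

Compound 4, `CCN(Cc1cccs1)C(=O)COc1ccc(C)cc1`, keeps the rest of compound 3 and differs in one place: hydrogen in place of methyl on a saturated chain carbon bound to an amide-type nitrogen and a saturated chain carbon. Compound 1 also bears ethyl on the amide-type nitrogen, but its ring differs, so its value cannot be read as a direct test of this step. With a single carbon removed from a group that proved sensitive, compound 4 is expected to need more compound than compound 3, by a 4.3-fold higher number from compound 3 to compound 4 (0.63 log units; beyond the scatter), a moderate step beyond the scatter. Compound 4 is therefore estimated at 300 nM, within 100 nM to 1500 nM.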

Compound 4, half-maximal effective concentration: 8 nM
For compound 4 the middle estimate is 38-fold (1.57 log units) above the measured one, and the stated range ends above it.
By their numbers in this assay, from the lowest: compound 4; then compound 3; then compound 2; then compound 1.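

In this assay, the shorter group does not cost potency: ethyl in place of isopropyl gives an 8.8-fold lower number from compound 3 to compound 4 (0.94 log units; beyond the scatter), and hydrogen in place of hydroxymethyl gives a 380-fold lower number from compound 2 to compound 4 (2.57 log units; beyond the scatter), so the number on this nitrogen does not simply rise as the group gets smaller. Among these compounds, with ethyl held constant, thiophen-2-yl in place of 1-methyl-1H-pyrrol-2-yl gives a 2700-fold lower number from compound 1 to compound 4 (3.43 log units; beyond the scatter), the first clean reading of this ring change, and it shows that the ring matters as well as the nitrogen substituent. Nothing available explains why either change moves the number this way.

The compounds shown leave open whether methyl or a straight propyl chain on this nitrogen would lower the number further. They also leave open how an amine or a carboxylic acid at the end of the chain would compare with the hydroxyl of compound 2.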